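The source may report more compounds than this note shows. Statements on the series, on what has been measured and on what is new or still open speak of the compounds shown alone.

Of the compounds shown here, three built on one shared core have been tested in a functional assay on MV cells (Homo sapiens) for inhibition, read by sulforhodamine B assay; a lower number here means a stronger inhibitor, a higher number a weaker inhibitor. Compound 1 `C#CC(=O)N1C(c2ccc(C#N)cc2)SC[C@@H]1C(=O)OCC` gives 2400 nM in this assay. Compound 2 `C#CC(=O)N1C(c2ccccc2F)SC[C@@H]1C(=O)OCC` gives 1700 nM in this assay. Compound 3 `C#CC(=O)N1C(C(C)(C)C)SC[C@@H]1C(=O)OCC` gives 900 nM in this assay, the lowest of the three numbers; the step of a 1.9-fold lower number from compound 2 to compound 3 (0.28 log units; within the scatter) stays within the scatter, while the gap from compound 1 to compound 3 lies beyond it.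

Compound 4 `C#CC(=O)N1C(c2ccc(F)cc2)SC[C@@H]1C(=O)OCC` has not yet been measured. Against compound 3 the change is 4-fluorophenyl in place of tert-butyl on a saturated ring carbon. Among the measured compounds shown here, only one measured step speaks to it, a 1.9-fold lower number from compound 2 to compound 3 (0.28 log units; within the scatter), which swapped an aromatic ring for the same tert-butyl in the opposite direction and remained within the scatter. Compound 4 runs that exchange back, with the fluorine placed as in 4-fluorophenyl rather than 2-fluorophenyl. Both aryl compounds already measured, compound 1 and compound 2, gave higher numbers than compound 3, so a modest rise is expected, though it need not exceed the scatter. The expected step of a 1.9-fold higher number from compound 3 to compound 4 (0.28 log units; within the scatter) is therefore small and upward. Compound 4 is estimated at 1700 nM in this assay, with a likely range from 800 nM to 3600 nM.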

Compound 4, half-maximal inhibitory concentration: 400 nM
Compound 4: middle estimate off by 4.3-fold (0.63 log units), on the high side; measured number below the stated range.
By their numbers in this assay, from the lowest: compound 4; then compounds 3, 2 and 1 (each within the scatter of the next, the first and the last beyond it).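

An aromatic ring on this saturated ring carbon carries no penalty of its own in this assay: the step of a 2.3-fold lower number from compound 3 to compound 4 (0.35 log units; beyond the scatter) shows that 4-fluorophenyl can outperform tert-butyl, which the earlier aryl compounds did not show. What the ring carries also counts, since 4-fluorophenyl in place of 2-fluorophenyl gives a 4.3-fold lower number from compound 2 to compound 4 (0.63 log units; beyond the scatter) and fluoro in place of cyano on an aromatic carbon gives a 6.0-fold lower number from compound 1 to compound 4 (0.78 log units; beyond the scatter) while the rest of the molecule stays the same. Compound 4 is therefore the strongest inhibitor of the four, but compound 1 and compound 2 go against any rule that a phenyl ring at this position is enough, and the gain belongs to this particular substituted ring.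

The compounds shown leave open whether the 4-position of the phenyl ring would tolerate something other than fluoro or cyano, such as a chlorine atom, a methoxy group or an amine, and whether a phenyl ring with no substituent would match compound 4. Nothing available here gives any independent measurement that would explain these differences.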